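Acyl variation in the series: from compound 3 to compound 4

The compounds below may be only part of what the source reports. "The series", "measured", "known", "first", "only" and "open" are said of these compounds alone.

Of the compounds shown here, three sharing one core have been measured so far. Compound 1 `CC(=O)N1N=C(c2ccc(-n3cncn3)cc2)CC1c1ccc(N(C)C)cc1` gives 11% in a functional assay on HCC1806 cells (Homo sapiens) for inhibition, read by sulforhodamine B assay, tested at 10 uM; a lower number here means less inhibition, a higher number more inhibition at the concentration tested (going by the name of the read-out). Compound 2 `CN(C)c1ccc(C2CC(c3ccc(-n4cncn4)cc3)=NN2C(=O)CCCl)cc1` gives -3.4% in this assay, and compound 3 `CN(C)c1ccc(C2CC(c3ccc(-n4cncn4)cc3)=NN2C(=O)c2ccc(F)cc2)cc1` gives 15.6% in the same assay. Compound 3 holds the highest of the three numbers; its nearest neighbour is compound 1, whose number lies within the scatter of it, while its furthest is compound 2, separated by a step beyond the scatter: a number 19 percentage points higher from compound 2 to compound 3 (beyond the scatter). The other step ending at compound 3, a number 4.6 percentage points higher from compound 1 to compound 3 (within the scatter), stays within the scatter.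

Compound 4 `CN(C)c1ccc(C2CC(c3ccc(-n4cncn4)cc3)=NN2C(=O)c2cc(Cl)cc(Cl)c2)cc1` is the next member, differing from compound 3 only at the carbonyl carbon: 3,5-dichlorophenyl in place of 4-fluorophenyl on a carbonyl carbon. For the measured compounds named here, the measured steps that touch this place are a number 4.6 percentage points higher from compound 1 to compound 3 (within the scatter) and a number 19 percentage points higher from compound 2 to compound 3 (beyond the scatter); both replace a non-aromatic group with the 4-fluorophenyl, and neither exchanges one aromatic ring for another, so no measured step directly matches the change to compound 4. Going by the values given here, the spread of all three numbers in this assay is modest, and the one aromatic acyl group already measured sits at the top of that spread. The step from compound 3 is therefore expected to be a number 0.4 percentage points higher from compound 3 to compound 4 (within the scatter), that is, none beyond the scatter. Compound 4 is estimated at 16%, with a range from 2% to 32%.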

Compound 4, a percentage reported as inhibition, at one concentration (the size of the read-out at that concentration, not a potency): 5.3%
Compound 4: the middle estimate sits 10.7 percentage points above what was measured; measured number inside the range.
By their numbers in this assay, from the lowest: compounds 2, 4, 1 and 3 (each within the scatter of the next, the first and the last beyond it).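

In this assay, for the compounds shown here, the exchange of one aromatic acyl ring for another registers at this carbonyl carbon for the first time: a number 10.3 percentage points lower from compound 3 to compound 4 (beyond the scatter). An aromatic ring on the carbonyl carbon therefore does not fix the read-out by itself, since a number 8.7 percentage points higher from compound 2 to compound 4 (within the scatter) and a number 5.7 percentage points lower from compound 1 to compound 4 (within the scatter), which leaves compound 4 within the scatter of both non-aromatic acyl compounds, whereas compound 3 stands clear of compound 2. Nothing measured on these compounds accounts for the step from 4-fluorophenyl to 3,5-dichlorophenyl.

The halogen, the number of halogens and their placing on the ring all change together in this step, so the compounds shown cannot say which of these matters; unsubstituted phenyl, 4-chlorophenyl or 3-chlorophenyl would separate them. Also open, as far as these compounds go, is whether any acyl group at this place moves the read-out well beyond the narrow band seen so far, for example a 4-methoxyphenyl, a pyridine ring, or a longer chain ending in an amine.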